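The source may hold more compounds than are shown below. What is called first, only, known or untested is meant among the compounds shown, and "the series" means these compounds.

Compound 1 `COc1ccc(C(=O)c2sc(N3CCCC3)nc2N)cc1OC`: 36000 nM
Compound 2 `COc1ccccc1C(=O)c1sc(N2CCCC2)nc1N`: 185000 nM

In a functional assay on HeLa cells (Homo sapiens) for antiproliferative activity, read by cell counting, with a stated time of 2 days (a lower number here means a stronger inhibitor, a higher number a weaker inhibitor), compound 2 gives 185000 nM, the higher of the two numbers. Compound 1 lies lower at 36000 nM, a gap beyond the usual scatter, so compound 2 is the weaker inhibitor of this pair.

Compound 3 `Nc1nc(N2CCCC2)sc1C(=O)c1ccccc1` has not yet been measured. It keeps the shared core of compound 2 but has hydrogen in place of methoxy on an aromatic carbon, ortho to a large group (hydrogen in place of methoxy on an aromatic carbon). Within the data shown here, no measured pair shows this change alone, so the expectation is loose. With compound 2 already at 185000 nM, a modest move toward a lower number seems more likely than a large one, and it may not clear the scatter. The expected change is a 1.7-fold lower number from compound 2 to compound 3 (0.23 log units; within the scatter). For compound 3 the estimated value is 110000 nM, with an expected range of 35000 nM to 300000 nM.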

Compound 3, half-maximal inhibitory concentration: > 200000 nM
Compound 3 was reported as a limit (the forecaster's own chance of this, stated with the estimate: 20%); middle value at least 1.8-fold (0.25 log units) away from the limit.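

In this assay compound 3 gives > 200000 nM, which is a limit of the assay and not a number. Hydrogen in place of methoxy on an aromatic carbon, ortho to a large group, gives an at least 1.0-fold higher number from compound 2 to compound 3 (0.03 log units; that floor lies within the scatter), so this change, now seen alone for the first time, brings no sign of a stronger inhibitor, while the true size of the step cannot be read. The readings in this series reach the end of the assay's range: the limit of > 200000 nM in this assay, at which 1 of the 3 values shown sits.

From the compounds shown here alone, whether the true values of these two compounds differ by more than the usual scatter remains open. Also open, going by these compounds, is whether another group at this place, such as an amine, a hydroxyl or a single fluorine atom, would give a lower number than methoxy does.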